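Changing the aryl on the pyrazole: from compound 2 to compound 3

This account rests on a few compounds, and the source may have more. Where it says the series, first, only, none or still open, it means among the compounds named here.

Measured compounds:
compound 1 `Cc1ccc(-c2c(C)nn(-c3nc(-c4ccc(Cl)c(Cl)c4)c(SC(C)C)s3)c2C(=O)O)cc1`, 3800 nM
compound 2 `Cc1nn(-c2nc(-c3ccc(Cl)c(Cl)c3)c(SC(C)C)s2)c(C(=O)O)c1-c1ccc(Cl)cc1`, 2500 nM

In a functional assay on BJAB cells (Homo sapiens) for antiproliferative activity, with a stated time of 4 days (on this read-out lower numbers stand for an effect already at smaller amounts and higher numbers for an effect only at larger amounts of compound), compound 2 gives 2500 nM, the lowest of the two numbers, though only a 1.5-fold lower number from compound 1 to compound 2 (0.18 log units; within the scatter). Compound 3 `Cc1nn(-c2nc(-c3ccc(Cl)c(Cl)c3)c(SC(C)C)s2)c(C(=O)O)c1-c1cccc(Cl)c1C` carries 3-chloro-2-methylphenyl in place of 4-chlorophenyl on an aromatic carbon. Among the compounds with values here, the one measured step, chloro for methyl, does not touch this position, so nothing measured bears directly on it. The expectation is therefore a number close to that of compound 2, with wide uncertainty: compound 3 is estimated at 3000 nM, between 1000 nM and 10000 nM, that is a 1.2-fold higher number from compound 2 to compound 3 (0.08 log units; within the scatter).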

Compound 3, half-maximal effective concentration: 5100 nM
Estimate against measurement, compound 3: 1.7-fold (0.23 log units) below; measured number inside the range.
By their numbers in this assay, from the lowest: compounds 2, 1 and 3 (each within the scatter of the next, the first and the last beyond it).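

In this assay, within the data shown here, putting 3-chloro-2-methylphenyl in place of 4-chlorophenyl gives a 2.0-fold higher number from compound 2 to compound 3 (0.31 log units; beyond the scatter), the first modest step at this position that clears the scatter. Set against 4-methylphenyl, the same group gives only a 1.3-fold higher number from compound 1 to compound 3 (0.13 log units; within the scatter), so the change registers against one of the two earlier aryl groups and not the other. Nothing available explains this difference. The compounds shown leave open whether the chloro or the methyl of the new group accounts for the step. They also leave open how 2-methylphenyl, 3-chlorophenyl or a pyridine ring would read at this position.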